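Chloro to Methyl on Compound 3

The source may report more compounds than this note shows. Statements on the series, on what has been measured and on what is new or still open speak of the compounds shown alone.

Within the data shown here, in a functional assay (plasma) for inhibition, with Homo sapiens as the target (a lower number here means a stronger inhibitor, a higher number a weaker inhibitor), compound 3 (`O=C(O)CCC/C=C\C[C@@H]1[C@@H](NS(=O)(=O)c2ccc(Cl)cc2)CC[C@@H]1O`) gives 190 nM, the lowest of the three numbers measured so far. Compound 2 (`O=C(O)CCC/C=C\C[C@@H]1[C@H](O)CC[C@H]1NS(=O)(=O)c1ccc(Cl)cc1`) gives 2200 nM, and compound 1 (`Cc1ccc(S(=O)(=O)N[C@H]2CC[C@H](O)[C@@H]2C/C=C\CCC(=O)O)cc1`) gives 2500 nM. Among the measured compounds shown here, the one step measured between compounds is large: a 12-fold lower number from compound 2 to compound 3 (1.06 log units; beyond the scatter). It traces to the fact that compounds 2 and 3 differ only in the configuration as drawn.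

Compound 4 (`Cc1ccc(S(=O)(=O)N[C@H]2CC[C@H](O)[C@@H]2C/C=C\CCCC(=O)O)cc1`) is compound 3 with a single group exchanged: methyl in place of chloro on an aromatic carbon. This places methyl in place of chloro on an aromatic carbon, para to a large group, and leaves the configuration of compound 3 untouched. The measured step therefore bears on this change only indirectly, since it concerns configuration, which stays the same here. For the measured compounds named here, compound 1 also bears the 4-methylphenyl group, but no measured step links it to compound 3 in one place. No measurement thus isolates the exchange of chloro for methyl, and the size of such a step has to be judged without a direct precedent.

Starting from compound 3 at 190 nM, only a small change is expected, with the estimated step of a 1.5-fold higher number from compound 3 to compound 4 (0.17 log units; within the scatter) remaining within the scatter. For compound 4 the estimated value in this assay is 280 nM, with an expected range of 100 nM to 800 nM.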

Compound 4, half-maximal inhibitory concentration: 500 nM
Compound 4: middle estimate off by 1.8-fold (0.25 log units), on the low side; low and high end bracket the measured number.
By their numbers in this assay, from the lowest: compound 3; then compound 4; then compounds 2 and 1 (each within the scatter of the next).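

In this assay, among these compounds, the exchange of 4-chlorophenyl for 4-methylphenyl now has a direct reading, which the earlier compounds could not supply: a 2.6-fold higher number from compound 3 to compound 4 (0.42 log units; beyond the scatter). Between these two compounds, the group at this place on the aromatic ring therefore makes a difference beyond the scatter, and it is the chloro compound that has the lower number. Among the compounds shown here, compound 4 also provides a first reading on the chain that ends in the acid, with the 4-methylphenyl group and the configuration held the same, as a 5.0-fold lower number from compound 1 to compound 4 (0.70 log units; beyond the scatter) shows that the carboxymethyl in place of carboxy matters too, while the information at hand explains neither step.

The compounds shown leave open how a bromo, methoxy or amine group at this place on the aromatic ring would compare with chloro and methyl, and whether the difference between those two groups would persist with the configuration of compound 2 or with the chain of compound 1. For the compounds shown here, they also leave open whether a longer chain than the one in compound 4 would continue the trend or reverse it.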